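Swapping the cyanosulfanyl group for a plain phenethyl chain

The compounds below may be only part of what the source reports. "The series", "measured", "known", "first", "only" and "open" are said of these compounds alone.

Compound 1 `N#CSc1ccc(CN2CCN(CCCN(c3ccc(F)cc3)c3ccc(F)cc3)CC2)cc1` gives 75.4 nM in an assay on isolated protein (strain Sprague-Dawley) for displacement of a labelled ligand from sodium-dependent dopamine transporter (Rattus norvegicus); on this read-out lower numbers stand for stronger inhibition and higher numbers for weaker inhibition. Compound 2 `N#CSc1ccc(CCCN2CCN(CCCN(c3ccc(F)cc3)c3ccc(F)cc3)CC2)cc1` gives 99.8 nM in this assay, and the change a 1.3-fold higher number from compound 1 to compound 2 (0.12 log units; within the scatter) shows that lengthening the chain at this place leaves the number within the scatter. Compound 3 `Fc1ccc(N(CCCN2CCN(CCCc3ccccc3)CC2)c2ccc(F)cc2)cc1` differs from compound 1 by phenethyl in place of 4-(cyanosulfanyl)phenyl on a saturated chain carbon bound to an amine nitrogen in a ring. Within the data shown here, no measured step removes the cyanosulfanyl group itself, so the only guide is that chain changes at this place mattered little. Compound 3 is therefore expected near 150 nM, between 50 nM and 500 nM, a step of a 2.0-fold higher number from compound 1 to compound 3 (0.30 log units; within the scatter).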

Compound 3, half-maximal inhibitory concentration: 19.5 nM
Estimate against measurement, compound 3: 7.7-fold (0.89 log units) above, and the stated range ends above it.
By their numbers in this assay, from the lowest: compound 3; then compounds 1 and 2 (each within the scatter of the next).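

Among these compounds, putting hydrogen in place of cyanosulfanyl on an aromatic carbon gives a 5.1-fold lower number from compound 2 to compound 3 (0.71 log units; beyond the scatter) in this assay and is the first change here that moves the number beyond the scatter. The swap of 4-(cyanosulfanyl)phenyl for phenethyl gives a 3.9-fold lower number from compound 1 to compound 3 (0.59 log units; beyond the scatter) and points the same way, whereas the chain change from compound 1 to compound 2 stayed within the scatter. No evidence here explains why removing this group lowers the number. From the compounds shown here alone, whether a chlorine, a methoxy group or an amine on that aromatic carbon would give a similar number remains open.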